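From tert-butyl to sec-butyl on the nitrogen

This account rests on a few compounds, and the source may have more. Where it says the series, first, only, none or still open, it means among the compounds named here.

In a functional assay on the whole organism for inhibition, with Brassica rapa subsp. chinensis as the target, with a stated time of 3 days, tested at 100 ppm (on this read-out lower numbers stand for less inhibition of growth and higher numbers for more inhibition of growth at the one concentration tested), compound 3 (`CC(C)(C)NC(=O)/C=C/c1ccccc1`) gives 34% and so stands in the middle of three numbers. Compound 1 (`CCCCCNC(=O)/C=C/c1ccccc1`) reaches 60% at the top, and compound 2 (`CCC(C)OC(=O)/C=C/c1ccccc1`) gives 18% at the bottom. Compound 4 (`CCC(C)NC(=O)/C=C/c1ccccc1`) carries sec-butyl in place of tert-butyl on an amide-type nitrogen. Among the measured compounds shown here, no measured step makes this exact change. Two bear on it: a number 26 percentage points lower from compound 1 to compound 3 (beyond the scatter) for tert-butyl in place of pentyl on that nitrogen, and a number 16 percentage points higher from compound 2 to compound 3 (beyond the scatter) for (tert-butyl)amino in place of sec-butoxy on a carbonyl carbon. For the measured compounds named here, compound 1 at 60% holds the only number above that of compound 3, so the expectation leans upward. The expected change is small, estimated as a number 8 percentage points higher from compound 3 to compound 4 (within the scatter) overall. For compound 4 the expected value is 42% (estimated range 28% to 57%).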

Compound 4, percent growth inhibition at one concentration: 56%
Estimate against measurement, compound 4: 14 percentage points below, and the stated range covers the measured number.
By their numbers in this assay, from the lowest: compound 2; then compound 3; then compounds 4 and 1 (each within the scatter of the next).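

Sec-butyl in place of tert-butyl on an amide-type nitrogen gives a number 22 percentage points higher from compound 3 to compound 4 (beyond the scatter) in this assay even though the two groups hold the same atoms, so this position responds to how those carbons are joined. Sec-butyl in place of pentyl gives a number 4 percentage points lower from compound 1 to compound 4 (within the scatter) and leaves the two chains unseparated here, while going from sec-butoxy to (sec-butyl)amino gives a number 38 percentage points higher from compound 2 to compound 4 (beyond the scatter) and is the largest step shown. Nothing given here accounts for these steps.

As far as these compounds go, whether a shorter chain such as ethyl or a ring such as cyclohexyl on that nitrogen would hold this level stays open.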